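The compounds below may be only part of what the source reports. "The series", "measured", "known", "first", "only" and "open" are said of these compounds alone.

For the measured compounds named here, in an assay on isolated protein for inhibition of histamine H2 receptor (Cavia porcellus) (a lower number here means tighter binding, a higher number weaker binding), compound 2 `COc1ccc(NC(=O)NCCCOc2cccc(CN3CCCCC3)c2)c(OC)c1` gives 2240 nM, the highest of the three numbers measured so far. Compound 1 `O=C(NCCCOc1cccc(CN2CCCCC2)c1)NCc1ccccc1` gives 347 nM and compound 3 `CCCNC(=O)NCCCOc1cccc(CN2CCCCC2)c1` gives 97.7 nM. Going by the values given here, two measured steps bear on a change at this position: a 6.5-fold higher number from compound 1 to compound 2 (0.81 log units; beyond the scatter) and a 23-fold lower number from compound 2 to compound 3 (1.36 log units; beyond the scatter). Both point the same way, with the 2,4-dimethoxyphenyl group on the amide-type nitrogen going with the weakest binding of the set, and a 3.6-fold lower number from compound 1 to compound 3 (0.55 log units; beyond the scatter) adds that the propyl chain gives the lowest number of the three. Compound 4 `O=C(NCCCOc1cccc(CN2CCCCC2)c1)Nc1cccc(Cl)c1` differs from compound 2 in one place: 3-chlorophenyl in place of 2,4-dimethoxyphenyl on an amide-type nitrogen. Because both a 6.5-fold higher number from compound 1 to compound 2 (0.81 log units; beyond the scatter) and a 23-fold lower number from compound 2 to compound 3 (1.36 log units; beyond the scatter) show a lower number whenever the 2,4-dimethoxyphenyl group is absent, a lower number is expected for compound 4 as well, though since the 3-chlorophenyl group keeps one six-membered aromatic ring, the expected step of a 4.5-fold lower number from compound 2 to compound 4 (0.65 log units; beyond the scatter) is judged modest rather than large. Compound 4 is therefore expected to give 500 nM in this assay, within a range from 150 nM to 1700 nM.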

Compound 4, dissociation constant: 316 nM
Estimate against measurement, compound 4: 1.6-fold (0.20 log units) above; the measured number falls inside the stated range.
By their numbers in this assay, from the lowest: compound 3; then compounds 4 and 1 (each within the scatter of the next); then compound 2.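

In this assay, with a six-membered aromatic ring kept directly on the amide-type nitrogen, 3-chlorophenyl in place of 2,4-dimethoxyphenyl still gives a clear change (a 7.1-fold lower number from compound 2 to compound 4 (0.85 log units; beyond the scatter)), so an aromatic ring at this place does not by itself go with the high number of compound 2. The 3-chlorophenyl and benzyl groups are not told apart here (a 1.1-fold lower number from compound 1 to compound 4 (0.04 log units; within the scatter)). The propyl group keeps the lowest number of the four compounds (a 3.2-fold higher number from compound 3 to compound 4 (0.51 log units; beyond the scatter)), and neither aromatic group shown matches it.

No measurement shown accounts for these differences. On these data alone, it remains open how an unsubstituted phenyl, a single methoxy group on the ring, or a longer chain such as butyl would stand against these numbers.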